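The source may hold more compounds than are shown below. What is called first, only, known or untested is meant among the compounds shown, and "the series" means these compounds.

In an ADME assay on J774.A1 cells (Mus musculus) for cytotoxicity, read by MTT assay, with a stated time of 72 h (a lower number here means that less compound is tolerated, a higher number that more compound is tolerated), compound 1 `CC1(c2ccc(-c3cccc(/C(N)=N\O)c3)cc2)CC(S(=O)(=O)c2ccc(F)cc2)=C(c2ccc(/C(N)=N\O)cc2)O1` gives 11000 nM, the lower of the two numbers recorded so far. Compound 2 `CC1(Cc2ccccc2)CC(S(=O)(=O)c2ccc(F)cc2F)=C(c2ccc(/C(N)=N\O)cc2)O1` gives 41500 nM in this assay, a value that lies beyond the scatter from that of compound 1. Compound 3 `COc1cc(-c2ccc(C3(C)CC(S(=O)(=O)c4ccc(F)cc4)=C(c4ccc(/C(N)=N\O)cc4)O3)cc2)cc(OC)c1OC` has not yet been measured. It differs from compound 1 in one place: a group of 12 heavy atoms (9 carbon, 3 oxygen; one six-membered aromatic ring of carbon only) in place of a group of 10 heavy atoms (7 carbon, 2 nitrogen, 1 oxygen; one six-membered aromatic ring of carbon only), on an aromatic carbon. Without a measured step of this kind to lean on, a moderate rise in this assay is expected for compound 3, so that the step of a 1.6-fold higher number from compound 1 to compound 3 (0.21 log units; within the scatter) is estimated to stay modest. Compound 3 is expected to give about 18000 nM, within 7000 nM to 45000 nM.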

Compound 3, half-maximal cytotoxic concentration: 5220 nM
Compound 3: the middle estimate sits 3.4-fold (0.54 log units) above what was measured; measured number below the stated range.
By their numbers in this assay, from the lowest: compound 3; then compound 1; then compound 2.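

Putting 3,4,5-trimethoxyphenyl on an aromatic carbon para to a large group, where compound 1 carries a group with 2 hydrogen-bond donors, gives a 2.1-fold lower number from compound 1 to compound 3 (0.32 log units; beyond the scatter) in this assay. The substituent at this position therefore matters to this reading: the change goes towards less compound being tolerated, though the step is modest. No measurement at hand bears on why the number moves.

This single step cannot separate the loss of the group in compound 1 from the entry of the new one. Going by these compounds, whether an amine or a carboxylic acid at this position would shift the number in the same direction remains open.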